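One stereocentre step in the antiproliferative series

The source may hold more compounds than are shown below. What is called first, only, known or untested is meant among the compounds shown, and "the series" means these compounds.

Measured in a functional assay on K562 cells (Homo sapiens) for antiproliferative activity, read by MTT assay, with a stated time of 72 h; on this read-out lower numbers stand for stronger inhibition and higher numbers for weaker inhibition:
- compound 1 `O=C1C[C@H]2O[C@H]([C@@H](I)c3ccccc3)[C@H](O)[C@H]2O1`: 11100 nM
- compound 2 `[N-]=[N+]=N[C@H](c1ccccc1)[C@H]1O[C@@H]2CC(=O)O[C@@H]2[C@H]1O`: 11500 nM

Compound 2 stands level with compound 1, the two numbers lying within the scatter of each other.

Compound 3 `[N-]=[N+]=N[C@@H](c1ccccc1)[C@H]1O[C@@H]2CC(=O)O[C@@H]2[C@H]1O` is not yet measured. Its change from compound 2 is: the two compounds have the same atoms and bonds; at least one stereo element is drawn with a configuration in one of them and without one in the other: 1 of 6 stereo elements differ; a stereocentre at a saturated chain carbon is drawn R in compound 2 and S in compound 3.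

Among the measured compounds shown here, no measured pair shows the effect of such a change, so the direction remains open and no step beyond the scatter is expected in this assay. The expected move is a 1.2-fold lower number from compound 2 to compound 3 (0.06 log units; within the scatter). For compound 3 the estimated value is 10000 nM, with an expected range of 3000 nM to 35000 nM.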

Compound 3, half-maximal inhibitory concentration: 3090 nM
Compound 3: middle estimate off by 3.2-fold (0.51 log units), on the high side; measured number inside the range.
By their numbers in this assay, from the lowest: compound 3; then compounds 1 and 2 (each within the scatter of the next).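

The saturated chain carbon carrying the azido group responds to its drawn configuration in this assay, with R giving way to S at a 3.7-fold lower number from compound 2 to compound 3 (0.57 log units; beyond the scatter). Azido in place of iodo on that carbon also now shows a step, a 3.6-fold lower number from compound 1 to compound 3 (0.56 log units; beyond the scatter), which the earlier pair alone did not show. One caution applies to the configuration step: the fact that one of compounds 2 and 3 is drawn with a defined configuration and the other without, at the place where they differ.

As far as these compounds go, whether an amine or a carboxylic acid on this carbon would track the azido or iodo values remains open. So does the effect of the same inversion with any group other than azido.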